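Allyl in place of methyl on a weak nucleoside analogue

The source may report more compounds than this note shows. Statements on the series, on what has been measured and on what is new or still open speak of the compounds shown alone.

Compound 1 `CSc1nc(N)nc2c1ncn2[C@@H]1C[C@H](O)[C@@H](CO)O1` is known in a functional assay on L1210 cells (Mus musculus) for inhibition (a higher number here means that more compound is needed for the effect, a lower number that less compound is needed), only through a limit: in this assay compound 1 gives > 100 uM, which is a limit of the assay and not a number. Its companion compound 2 `CSc1nc(N)nc2c1ncn2[C@H]1C[C@H](O)[C@@H](CO)O1` shares every atom and bond with compound 1 and differs only in the configuration drawn at one saturated ring carbon; in this assay compound 2 gives 24 uM. Among the compounds with values here, the one measured step, an at least 4.1-fold lower number from compound 1 to compound 2 (0.61 log units; beyond the scatter), therefore separates the two drawn configurations, and its size is known only as a lower bound because the limit of > 100 uM in this assay, at which 1 of the 2 values shown sits, and (the fact that compounds 1 and 2 differ only in the configuration as drawn).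

Compound 3 `C=CCSc1nc(N)nc2c1ncn2[C@@H]1C[C@H](O)[C@@H](CO)O1` keeps the configuration of compound 1 and changes the substituent instead: vinyl in place of hydrogen on a saturated chain carbon bound to a sulfur. Within the data shown here, no measured step concerns this kind of change, so the measured step gives no guide to its size or direction. With compound 1 itself standing at the limit, compound 3 is expected to remain in the same weak region, the step from compound 1 being estimated as a step that the limit leaves unreadable from compound 1 to compound 3. The value expected for compound 3 in this assay is 150 uM, within a range from 40 uM to 600 uM, with a real chance that only a limit is again reported.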

Compound 3, concentration for half-maximal effect: > 100 uM
Compound 3 ended at the assay's limit (the forecaster's own chance of this, stated with the estimate: 65%); the middle value lies beyond the limit too.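

In this assay, within the data shown here, compound 3 gives > 100 uM, a limit of the assay and not a number, as compound 1 also gives, so no step between the two can be read. The compounds shown leave open whether allylsulfanyl in place of methylsulfanyl shifts the number at all, and what it would do in the configuration drawn in compound 2.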